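Chloro on the pendant phenyl of compound 2

The source may hold more compounds than are shown below. What is called first, only, known or untested is meant among the compounds shown, and "the series" means these compounds.

Compound 2 `O=C(/C=C/c1cccc(O)c1)c1cccc(-n2cc(-c3ccccc3)[nH]c2=O)c1` carries a 3-hydroxyphenyl on the double-bonded chain and an unsubstituted phenyl on the shared core. In a functional assay on ACHN cells (Homo sapiens) for inhibition (on this read-out lower numbers stand for stronger inhibition of growth and higher numbers for weaker inhibition of growth), compound 2 gives 2760 nM, the highest of the two numbers at hand; its nearest neighbour is compound 1 `COc1cc(/C=C/C(=O)c2cccc(-n3cc(-c4ccccc4)[nH]c3=O)c2)ccc1O`, which in this assay gives 2500 nM. Going by the values given here, the only measured step, a 1.1-fold higher number from compound 1 to compound 2 (0.04 log units; within the scatter), concerns the chain end alone. Compound 3 `O=C(/C=C/c1cccc(O)c1)c1cccc(-n2cc(-c3ccc(Cl)cc3)[nH]c2=O)c1` differs from compound 2 in one place: chloro in place of hydrogen on an aromatic carbon, on an aromatic carbon of a six-membered aromatic ring of carbon only, para to a large group. Among the compounds with values here, no measured step touches this ring, so the data give no direction for the change; a step within the scatter is therefore expected, a 1.3-fold lower number from compound 2 to compound 3 (0.10 log units; within the scatter). Compound 3 is estimated at 2200 nM, with a range from 800 nM to 6000 nM.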

Compound 3, concentration for 50% growth inhibition: 1840 nM
Compound 3: the middle estimate sits 1.2-fold (0.08 log units) above what was measured, within the range that was stated.
By their numbers in this assay, from the lowest: compounds 3, 1 and 2 (each within the scatter of the next).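

The pendant phenyl now has its first reading, as the earlier step concerned the chain end alone: in this assay, phenyl to 4-chlorophenyl gives a 1.5-fold lower number from compound 2 to compound 3 (0.18 log units; within the scatter). On this read-out, chloro is therefore accepted on this aromatic carbon, para to a large group, with the two numbers staying within the scatter of each other. Nothing at hand accounts for the size of this step.

One chloro cannot define the scope of this position, so an amine, a carboxylic acid or a methoxy group at the same carbon would show whether numbers in this range hold for other groups. Going by these compounds, it is also open whether chloro gives a similar step when the chain end carries the 4-hydroxy-3-methoxyphenyl group of compound 1.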